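A Shorter Amide on a Compound at the Limit

A few compounds are considered here, and "the series" means these few. Any claim that something is new, unique, unknown or untested is made for them only; others in the source may bear on it.

In a functional assay on Ishikawa cells (Homo sapiens) for antiproliferative activity, read by CCK-8 assay, with a stated time of 48 h (a higher number here means a weaker inhibitor, a lower number a stronger inhibitor), compound 1 (`CNC(=O)/C=C/CN1CC(Oc2ccc(Oc3c(-c4ccc(F)cc4)sc4cc(O)ccc34)cc2)C1`) gives > 25000 nM, which is a limit and not a number. Compound 2 (`O=C(CCCNCCOc1ccc(Oc2c(-c3ccc(F)cc3)sc3cc(O)ccc23)cc1)N1CCC1`) gives > 25000 nM, also only a limit. For the measured compounds named here, the one measured step is a step that the two limits leave unreadable from compound 1 to compound 2, so it offers no size to build on. Compound 3 (`C/C=C/C(=O)NCCOc1ccc(Oc2c(-c3ccc(F)cc3)sc3cc(O)ccc23)cc1`) carries (prop-1-en-1-yl)carbonyl in place of 3-((azetidin-1-yl)carbonyl)propyl on an amine nitrogen, a change counted as (prop-1-en-1-yl)carbonyl in place of 3-((azetidin-1-yl)carbonyl)propyl on an amine nitrogen. Going by the values given here, the only guide in this assay is the limit of > 25000 nM in this assay, at which 2 of the 2 values shown sit. On that thin evidence, no clear direction can be expected, and compound 3 will probably stay near that limit, perhaps reported only as a limit itself. The expected change is an at least 1.1-fold lower number from compound 2 to compound 3 (0.05 log units; that floor lies within the scatter), and this is an estimate with little behind it. For compound 3 the estimated value is 22000 nM, with an expected range of 8000 nM to 60000 nM.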

Compound 3, half-maximal inhibitory concentration: 12400 nM
Compound 3: middle estimate off by 1.8-fold (0.25 log units), on the high side, and the stated range covers the measured number.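

In this assay, for the compounds shown here, compound 3 is the first compound here to give a number rather than a limit: putting (prop-1-en-1-yl)carbonyl, which has no ring, in place of 3-((azetidin-1-yl)carbonyl)propyl on an amine nitrogen gives an at least 2.0-fold lower number from compound 2 to compound 3 (0.30 log units; that floor lies within the scatter). The larger change on an oxygen on an aromatic ring gives an at least 2.0-fold lower number from compound 1 to compound 3 (0.30 log units; that floor lies within the scatter), while the step between the two earlier compounds cannot be read. Each of the two new steps starts from a limit, so its true size stays unknown, and the series still rests mostly on limits: the limit of > 25000 nM in this assay, at which 2 of the 3 values shown sit.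

The compounds shown do not tell whether the double bond matters or the carbonyl on that nitrogen is enough, which a saturated butanoyl group there would separate. They also leave open whether a longer chain on that carbonyl would lower the number.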